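This account rests on a few compounds, and the source may have more. Where it says the series, first, only, none or still open, it means among the compounds named here.

Three compounds share one core and differ only in the group on the ring nitrogen. All were tested in an assay on HEK293 cells for inhibition of Voltage-dependent T-type calcium channel subunit alpha-1G (Homo sapiens), read by fluorescence, tested at 10 uM; a lower number here means less inhibition, a higher number more inhibition at the concentration tested (going by the name of the read-out):

compound 1 `CCCc1nc(-c2ccccc2)c(CNCCCN2CCN(c3cccc(C)c3C)CC2)o1` gives 55.2%
compound 2 `CCCc1nc(-c2ccccc2)c(CNCCCN2CCN(c3ccccc3)CC2)o1` gives 43.7%
compound 3 `CCCc1nc(-c2ccccc2)c(CNCCCN2CCN(c3ccccc3OC)CC2)o1` gives 41%

Compound 3 sits at the low end of these three numbers; its gap to compound 2 is within the usual scatter, while its gap to compound 1 is beyond it. Two steps lead to compound 3: a number 14.2 percentage points lower from compound 1 to compound 3 (beyond the scatter) and a number 2.7 percentage points lower from compound 2 to compound 3 (within the scatter).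

Compound 4 `CCCc1nc(-c2ccccc2)c(CNCCCN2CCN(c3ccc(Cl)cc3)CC2)o1` has not yet been measured. It differs from compound 3 in one place: 4-chlorophenyl in place of 2-methoxyphenyl on an amine nitrogen in a ring. Going by the values given here, the step that bears most directly on this change is the one from compound 2 to compound 3, which shows that adding or removing the methoxy group leaves the number essentially unchanged. Among the compounds with values here, no measured compound carries a chlorine, so nothing here tells what that group does. The step from compound 1 to compound 2 shows that exchanging the group on the ring nitrogen can move the number modestly. The expected step in this assay is therefore small, a number 4 percentage points higher from compound 3 to compound 4 (within the scatter), with no clear direction. Compound 4 is expected to give about 45%, most likely between 32% and 58%.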

Compound 4, a percentage reported as inhibition, at one concentration (the size of the read-out at that concentration, not a potency): 63.3%
Compound 4: the middle estimate sits 18.3 percentage points below what was measured; measured number outside the range, above it.
By their numbers in this assay, from the lowest: compounds 3 and 2 (each within the scatter of the next); then compounds 1 and 4 (each within the scatter of the next).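

Going by these compounds alone, replacing hydrogen with chloro on the phenyl group on the ring nitrogen changes the reading in this assay (a number 19.6 percentage points higher from compound 2 to compound 4 (beyond the scatter)), whereas the methoxy change among the earlier compounds stayed within the scatter, so a single added group at this position can matter. The exchange of 2-methoxyphenyl for 4-chlorophenyl points the same way (a number 22.3 percentage points higher from compound 3 to compound 4 (beyond the scatter)), and 4-chlorophenyl reads level with the two-methyl group of compound 1 (a number 8.1 percentage points higher from compound 1 to compound 4 (within the scatter)), so two quite different groups reach a similar reading, well clear of the plain phenyl of compound 2. Nothing measured here accounts for these differences.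

Compound 3 and compound 4 differ both in the group and in where it sits on the phenyl ring, so these compounds cannot separate the effect of the chlorine from the effect of its place. On these data alone, it also remains open whether bromo or trifluoromethyl on the same ring would give a similar reading, or whether the rise belongs to chloro alone.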